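Swapping a Nitrophenyl for a Cyclopentyl on an Amide

The source may hold more compounds than are shown below. What is called first, only, known or untested is meant among the compounds shown, and "the series" means these compounds.

Measured so far:
- compound 1 `Cc1cccc(Cn2c(CN3CCN(C(=O)c4ccc([N+](=O)[O-])cc4)CC3)nc3ccccc32)c1`: 24.3%
- compound 2 `CCn1c(CN2CCN(C(=O)C3CC3)CC2)nc2ccccc21`: 20.8%
- compound 3 `Cc1cccc(Cn2c(OC3CCN(C(=O)c4ccco4)CC3)nc3ccccc32)c1`: 68.3%

In an assay on isolated protein for inhibition of aldehyde dehydrogenase 1A1 (Homo sapiens), read by spectrophotometry, tested at 10 uM (a lower number here means less inhibition, a higher number more inhibition at the concentration tested (going by the name of the read-out)), compound 1 gives 24.3%, the second highest of the three numbers. Compound 2 sits nearby, with a value that lies within the usual scatter of compound 1, so the two cannot be told apart. Compound 3 stands well beyond the scatter above compound 1.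

Compound 4 `Cc1cccc(Cn2c(CN3CCN(C(=O)C4CCCC4)CC3)nc3ccccc32)c1` is not yet measured. It differs from compound 1 in one place: cyclopentyl in place of 4-nitrophenyl on a carbonyl carbon. Among the measured compounds shown here, no measured pair shows this exact change, so its effect has to be guessed. Compound 2, which also carries a small carbon ring on an amide carbonyl, gives 20.8%, a number close to compound 1. The expectation is therefore a step from compound 1 to compound 4 of a number 2.3 percentage points lower from compound 1 to compound 4 (within the scatter), that is, no change beyond the scatter. Compound 4 is estimated at 22% in this assay, with a likely range from 8% to 40%.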

Compound 4, a percentage reported as inhibition, at one concentration (the size of the read-out at that concentration, not a potency): 67.5%
For compound 4 the middle estimate is 45.5 percentage points below the measured one; the whole stated range lies below it.
By their numbers in this assay, from the lowest: compounds 2 and 1 (each within the scatter of the next); then compounds 4 and 3 (each within the scatter of the next).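

Cyclopentyl in place of 4-nitrophenyl on a carbonyl carbon gives a number 43.2 percentage points higher from compound 1 to compound 4 (beyond the scatter) in this assay. This is the only pair shown that differs in one place, and it shows that the group on this amide carbonyl can by itself move the inhibition well beyond the usual scatter while the rest of the structure stays fixed. Nothing available explains why the swap has so large an effect.

The change removes an aromatic ring and its nitro group together, so the pair cannot say which of the two matters; a plain phenyl on the same carbonyl would separate them. Also open, as far as these compounds go, is how an open hexyl chain, or a cyclopentyl ring carrying an amine, would behave at this position.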